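This account rests on a few compounds, and the source may have more. Where it says the series, first, only, none or still open, it means among the compounds named here.

Three compounds share one core. Compound 1 `COc1cc(C(F)(F)F)cc(SC)c1C(=O)NC1(c2ccccc2)CCCN(C)C1` gives in an assay on cells for inhibition of sodium- and chloride-dependent glycine transporter 1 (Homo sapiens) (on this read-out lower numbers stand for an effect already at smaller amounts and higher numbers for an effect only at larger amounts of compound), a value of 24 nM. Compound 2 `COc1ccc(C2(NC(=O)c3c(OC)cc(C(F)(F)F)cc3SC)CCCN(C)C2)cc1` gives 170 nM in this assay, and compound 3 `COc1cc(C(F)(F)F)cc(SC)c1C(=O)NC1(c2cnccn2)CCCN(C)C1` gives 1670 nM. Compound 3 thus stands at the highest number of the three: compound 2 lies nearest, and the step of a 9.8-fold higher number from compound 2 to compound 3 (0.99 log units; beyond the scatter) is modest, while compound 1 lies furthest, the step of a 70-fold higher number from compound 1 to compound 3 (1.84 log units; beyond the scatter) being large.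

Compound 4 `COc1cc(C(F)(F)F)cc(SC)c1C(=O)NC1(c2ncccn2)CCCN(C)C1` is not yet measured. It differs from compound 3 in one place: pyrimidin-2-yl in place of pyrazin-2-yl on a saturated ring carbon. Within the data shown here, no measured pair shows this particular exchange of one six-membered aromatic ring with two hetero atoms for another. The steps of a 70-fold higher number from compound 1 to compound 3 (1.84 log units; beyond the scatter) and a 9.8-fold higher number from compound 2 to compound 3 (0.99 log units; beyond the scatter) concern the entry of pyrazin-2-yl itself and only frame what compound 3 is, so they bear on compound 4 indirectly. Since the two rings match in their counted atoms, donors and acceptors, the step from compound 3 to compound 4 is expected to be small, a 1.1-fold lower number from compound 3 to compound 4 (0.05 log units; within the scatter), within or near the scatter. Compound 4 is therefore estimated at 1500 nM in this assay, within a range from 500 nM to 4500 nM.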

Compound 4, half-maximal effective concentration: > 10000 nM
Compound 4 ended at the assay's limit (the forecaster's own chance of this, stated with the estimate: 5%); middle value at least 6.6-fold (0.82 log units) away from the limit.
By their numbers in this assay, from the lowest: compound 1; then compound 2; then compound 3. At a limit, above all of these: compound 4.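

In this assay, among these compounds, compound 4 gives > 10000 nM, which is a limit of the assay and not a number: the limit of > 10000 nM in this assay, at which 1 of the 4 values shown sits. The earlier compounds showed only that a ring with two hetero atoms at this saturated ring carbon raises the number relative to phenyl, whereas here two rings with the same counted atoms, donors and acceptors still differ, with an at least 5.9-fold higher number from compound 3 to compound 4 (0.77 log units; beyond the scatter), so the way the ring atoms are joined matters by itself. Pyrimidin-2-yl also extends the steps seen for pyrazin-2-yl, with an at least 58-fold higher number from compound 2 to compound 4 (1.76 log units; beyond the scatter) and an at least 410-fold higher number from compound 1 to compound 4 (2.61 log units; beyond the scatter), and no compound shown goes against this order.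

On these data alone, how far compound 4 lies past its limit stays open. As far as these compounds go, it is also open where pyridin-2-yl or pyridin-3-yl, each with a single ring nitrogen, would fall between phenyl and these two rings.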